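The source may hold more compounds than are shown below. What is called first, only, known or untested is meant among the compounds shown, and "the series" means these compounds.

Compound 1 `NC(CCSCCNCC(=O)O)C(=O)O` appears in this set without a number: in an assay for inhibition of betaine--homocysteine S-methyltransferase 1 (Homo sapiens) (a lower number here means a stronger inhibitor, a higher number a weaker inhibitor), compound 1 gives "not determined" (no result reported). For the measured compounds named here, compound 2 `CC(C)(CCSCCC(N)C(=O)O)CC(=O)O` therefore provides the only number available: in this assay compound 2 gives 84 nM. Compound 3 `CC(C)(CCSCC[C@H](N)C(=O)O)CC(=O)O` keeps every atom and bond of compound 2 and differs only in that (the two compounds have the same atoms and bonds; at least one stereo element is drawn with a configuration in one of them and without one in the other: 1 of 1 stereo elements differ; a stereocentre at a saturated chain carbon is drawn without a configuration in compound 2 and S in compound 3). Going by the values given here, no measured pair in this set reports what fixing such a configuration does, so the expectation rests on the single value of compound 2. The author expects the step from compound 2 to compound 3 in this assay to be a 1.7-fold lower number from compound 2 to compound 3 (0.23 log units; within the scatter), a modest gain toward the stronger side that may not exceed the scatter. For compound 3 the estimate in this assay is 50 nM, within 20 nM to 150 nM.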

Compound 3, half-maximal inhibitory concentration: 64 nM
Estimate against measurement, compound 3: 1.3-fold (0.11 log units) below; the measured number falls inside the stated range.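

In this assay, for the compounds shown here, this is the first measured pair at this stereocentre, and it gives a 1.3-fold lower number from compound 2 to compound 3 (0.12 log units; within the scatter), so drawing the saturated chain carbon as S leaves the number within the scatter of the undefined drawing. The pair therefore shows no measurable effect of this change, and the only structural difference between the two compounds is this: the fact that one of compounds 2 and 3 is drawn with a defined configuration and the other without, at the place where they differ

The compounds shown leave open how the R configuration at this carbon would read in this assay. They also leave open what an amide in place of the terminal carboxylic acid would do.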